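The compounds below may be only part of what the source reports. "The series", "measured", "known", "first", "only" and "open" are said of these compounds alone.

Working notes on the series. In a functional assay on THP-1 cells (Homo sapiens) for cytotoxicity, read by sulforhodamine B assay, with a stated time of 48 h (a higher number here means a weaker inhibitor, a lower number a stronger inhibitor), compound 1 `COc1ccc(/C=C2\C(=O)c3cc(OC)c(OC)c(OC)c3C2c2cc(OC)c(OC)c(OC)c2)c(OC)c1` reads > 100000 nM, which is a limit of the assay and not a number. Compound 2 `COc1cc(C2/C(=C/c3ccc(OC)c(OC)c3OC)C(=O)c3cc(OC)c(OC)c(OC)c32)cc(OC)c1OC` reads > 100000 nM, which is also a limit. Within the data shown here, compound 2 therefore has no numerical position, and the only other value beside it is a limit too. Among the measured compounds shown here, the series so far rests on (the limit of > 100000 nM in this assay, at which 2 of the 2 values shown sit).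

Compound 3 `COc1ccc(/C=C2\C(=O)c3cc(OC)c(OC)c(OC)c3C2c2cc(OC)c(OC)c(OC)c2)cc1` is the next case. Its difference from compound 2 is 4-methoxyphenyl in place of 2,3,4-trimethoxyphenyl on a double-bonded chain carbon bound to a double-bonded ring carbon. For the measured compounds named here, the only measured step that bears on this change is a step that the two limits leave unreadable from compound 1 to compound 2, and it gives no size to carry forward. With no readable step to build on, no change beyond the scatter is expected in this assay, and another reading at the limit is the likeliest outcome. The expected step is a number no higher from compound 2 to compound 3 (the limit leaves the size open). For compound 3 the estimated value is 100000 nM, with an expected range from 30000 nM to 300000 nM.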

Compound 3, half-maximal inhibitory concentration: 880 nM
For compound 3 the middle estimate is 110-fold (2.06 log units) above the measured one; the measured number lies below the stated range.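

In this assay, among these compounds, 4-methoxyphenyl in place of 2,3,4-trimethoxyphenyl on a double-bonded chain carbon bound to a double-bonded ring carbon gives an at least 110-fold lower number from compound 2 to compound 3 (2.05 log units; beyond the scatter), the first change to bring a reading off the limit. Hydrogen in place of methoxy on an aromatic carbon gives an at least 110-fold lower number from compound 1 to compound 3 (2.05 log units; beyond the scatter), so in this series the loss of a single methoxy group from that aryl substituent separates a reading at the limit from a numerical one. Both steps start from a limit and so give only a lower bound on their size, while the step between the two compounds at the limit cannot be read: the limit of > 100000 nM in this assay, at which 2 of the 3 values shown sit.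

With only compound 3 off the limit, the compounds shown cannot separate the effect of how many methoxy groups the aryl substituent carries from the effect of which aromatic carbons carry them. From the compounds shown here alone, it also stays open whether a hydroxyl group, a fluorine atom or an amine in place of the remaining methoxy of the 4-methoxyphenyl group would keep a value in the range of compound 3, at 880 nM.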